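The source may hold more compounds than are shown below. What is called first, only, known or untested is meant among the compounds shown, and "the series" means these compounds.

Compound 1 `OCCCc1cn(CCNc2nonc2/C(=N/O)Nc2ccc(F)c(Br)c2)nn1` and compound 2 `OCCCCc1cn(CCNc2nonc2/C(=N/O)Nc2ccc(F)c(Br)c2)nn1` share one core and differ only in the chain carrying the hydroxy group. In an assay on isolated protein for inhibition of Indoleamine 2,3-dioxygenase 1 (Homo sapiens) (a higher number here means a weaker inhibitor, a lower number a stronger inhibitor), compound 1 gives 98 nM, and compound 2 gives 80 nM. The step of a 1.2-fold lower number from compound 1 to compound 2 (0.09 log units; within the scatter) shows that lengthening that chain left the result essentially unchanged; the two numbers sit within the scatter of each other, so neither compound can be called the stronger of the pair. Compound 3 `CCC(O)c1cn(CCNc2nonc2/C(=N/O)Nc2ccc(F)c(Br)c2)nn1` carries the change (1-hydroxypropyl in place of 4-hydroxybutyl on an aromatic carbon). Going by the values given here, the only measured step that bears on it is the one from compound 1 to compound 2, which also moved the hydroxy group along this chain and stayed within the scatter. On that basis the step of a 1.2-fold higher number from compound 2 to compound 3 (0.07 log units; within the scatter) is expected to be small. Compound 3 is therefore estimated at 95 nM in this assay, most likely between 40 nM and 230 nM.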

Compound 3, half-maximal inhibitory concentration: 73 nM
Estimate against measurement, compound 3: 1.3-fold (0.11 log units) above; the range from low to high includes it.
By their numbers in this assay, from the lowest: compounds 3, 2 and 1 (each within the scatter of the next).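

In this assay, putting 1-hydroxypropyl in place of 4-hydroxybutyl gives a 1.1-fold lower number from compound 2 to compound 3 (0.04 log units; within the scatter), and putting it in place of 3-hydroxypropyl gives a 1.3-fold lower number from compound 1 to compound 3 (0.13 log units; within the scatter). The earlier pair showed only that the chain could be lengthened with the hydroxy group kept at its far end; these steps show that, among these three compounds, moving the hydroxy group to the first carbon of the chain also gives a number within the scatter of the others. Nothing available explains why these three compounds read so alike.

All three compounds carry a hydroxy group, so they leave open whether a plain propyl chain with no oxygen would give a similar number. On these data alone, how an amine, a carboxylic acid or a much longer chain at this position would read in this assay also remains open.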